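Methyl in place of hydroxyl hydrogen in a pyrazole urea series

This account rests on a few compounds, and the source may have more. Where it says the series, first, only, none or still open, it means among the compounds named here.

Measured compounds:
Compound 1 `COc1cc(Cl)cc(-c2nn(-c3cccc(NC(=O)Nc4cccc(C(F)(F)F)c4)c3)cc2-c2ccncc2)c1` — 45%
Compound 2 `O=C(Nc1cccc(-n2cc(-c3ccncc3)c(-c3cc(O)cc(Cl)c3)n2)c1)Nc1ccc(Cl)c(Cl)c1` — 58%

In a functional assay on NCI-H460 cells (Homo sapiens) for inhibition, read by sulforhodamine B assay, with a stated time of 48 h, tested at 1 uM (on this read-out higher numbers stand for a weaker effect at the one concentration tested and lower numbers for a stronger effect), compound 1 gives 45%. Compound 2, in this assay, gives 58%, which is the higher of the two numbers, and the gap to compound 1 lies beyond the scatter. No single-point step between the two measured compounds can be drawn, since they differ in more than one place, so the two values are simply shown side by side.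

Compound 3 `COc1cc(Cl)cc(-c2nn(-c3cccc(NC(=O)Nc4ccc(Cl)c(Cl)c4)c3)cc2-c2ccncc2)c1` has not yet been measured in this assay. It differs from compound 2 by one change: methyl in place of hydrogen on an oxygen on an aromatic ring. Going by the values given here, compound 1 carries the same methoxy group, but with a different urea partner, so it gives no direct step. The expected step is small, a number 6 percentage points lower from compound 2 to compound 3 (within the scatter), possibly none beyond the scatter. Compound 3 is estimated at 52%, with a range from 35% to 70%.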

Compound 3, a percentage reported as activity, at one concentration (the size of the read-out at that concentration, not a potency): 77%
Estimate against measurement, compound 3: 25 percentage points below, outside the stated range (above it).
By their numbers in this assay, from the lowest: compound 1; then compound 2; then compound 3.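

In this assay the hydrogen on this oxygen proves not to be a neutral position: methyl in its place gives a number 19 percentage points higher from compound 2 to compound 3 (beyond the scatter) and so a weaker effect at the one concentration tested. With the 3-chloro-5-methoxyphenyl group held constant, the urea partner also counts, since 3,4-dichlorophenyl in place of 3-(trifluoromethyl)phenyl on the amide-type nitrogen gives a number 32 percentage points higher from compound 1 to compound 3 (beyond the scatter) and again a weaker effect. Nothing available explains either step.

From the compounds shown here alone, what an ethoxy group, an amine or a carboxylic acid would give in place of the hydroxy group remains open. So does whether the change from hydroxy to methoxy would have the same effect alongside the 3-(trifluoromethyl)phenyl partner of compound 1.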